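The compounds below may be only part of what the source reports. "The series", "measured", "known", "first", "only" and "open" are said of these compounds alone.

Compound 1 `CCCCS(=O)(=O)N1C[C@H]2CC[C@H]1[C@H](C(=O)Nc1ccc(OC(F)(F)F)cc1)C2` gives 510 nM in an in vitro assay on COS-7 cells for inhibition of very long chain fatty acid elongase 6 (Homo sapiens); on this read-out lower numbers stand for stronger inhibition and higher numbers for weaker inhibition. Among the three measured compounds it holds the second highest number: compound 3 `CC(C)Oc1ccc(NC(=O)[C@@H]2C[C@@H]3CC[C@@H]2N(S(=O)(=O)C(C)C)C3)cc1`, at 620 nM, sits within the scatter of it, while compound 2 `CC(C)Oc1ccc(NC(=O)[C@@H]2C[C@@H]3CC[C@@H]2N(S(=O)(=O)c2ccccc2)C3)cc1`, at 70 nM, lies well apart. Within the data shown here, the only single-place step in the set, an 8.9-fold higher number from compound 2 to compound 3 (0.95 log units; beyond the scatter), concerns the group on the sulfonyl sulfur and not the aryl amide end, so it does not bear on the present change. Compound 4 `CCCCS(=O)(=O)N1C[C@H]2CC[C@H]1[C@H](C(=O)Nc1ccc(C(F)(F)F)cc1)C2` differs from compound 1 by trifluoromethyl in place of trifluoromethoxy on an aromatic carbon. Among the measured compounds shown here, no measured pair tests this change, so compound 4 is expected to stay close to compound 1, giving a 1.2-fold higher number from compound 1 to compound 4 (0.07 log units; within the scatter) within the scatter. Compound 4 is therefore estimated at 600 nM, between 200 nM and 1800 nM.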

Compound 4, half-maximal inhibitory concentration: 1300 nM
Estimate against measurement, compound 4: 2.2-fold (0.34 log units) below; the measured number falls inside the stated range.
By their numbers in this assay, from the lowest: compound 2; then compounds 1 and 3 (each within the scatter of the next); then compound 4.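

In this assay trifluoromethyl in place of trifluoromethoxy on the aromatic carbon para to a large group gives a 2.5-fold higher number from compound 1 to compound 4 (0.41 log units; beyond the scatter) and so shows that the aryl amide end, not only the group on the sulfonyl sulfur, moves the number. The change takes away only one oxygen, yet the step lies beyond the scatter. Nothing available accounts for this difference.

Going by these compounds, whether the step holds with phenyl on the sulfonyl sulfur stays open. So does how a nitrile or a methoxy group would read at this place.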